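The source may hold more compounds than are shown below. What is called first, only, known or untested is meant among the compounds shown, and "the series" means these compounds.

Compounds measured in a functional assay for antagonist activity at transient receptor potential cation channel subfamily V member 1 (Homo sapiens), read by FLIPR and calcium flux; a lower number here means a stronger inhibitor, a higher number a weaker inhibitor: compound 1 `O=C(Nc1cccc2[nH]ccc12)C1CCN(c2cccc(C(F)(F)F)c2)CC1` gives 230 nM; compound 2 `O=C(Nc1ccc2c(c1)NC(=O)C(CCO)O2)C1CCN(c2cc(F)c(F)c(F)c2)CC1` gives 5 nM; compound 3 `O=C1COc2ccc(NC(=O)C3CCN(c4ccccc4Br)CC3)cc2N1` gives 160 nM.

Compound 3 holds the second highest of the three numbers. Its nearest neighbour is compound 1, whose value lies within the scatter of that of compound 3, so no order between the two can be read. Compound 2 sits far lower, beyond the scatter, and is the strongest inhibitor of the three.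

Compound 4 `Cc1cccc(N2CCC(C(=O)Nc3ccc4c(c3)NC(=O)CO4)CC2)c1C` keeps the core of compound 3 and carries one change: 2,3-dimethylphenyl in place of 2-bromophenyl on an amine nitrogen in a ring. For the measured compounds named here, no measured pair shows this change, so the step from compound 3 to compound 4 in this assay is expected to be small, a 1.2-fold lower number from compound 3 to compound 4 (0.09 log units; within the scatter), and not clearly beyond the scatter. Compound 4 is therefore estimated at 130 nM, with a range from 40 nM to 400 nM.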

Compound 4, half-maximal inhibitory concentration: 60 nM
Compound 4: the middle estimate sits 2.2-fold (0.34 log units) above what was measured, and the stated range covers the measured number.
By their numbers in this assay, from the lowest: compound 2; then compound 4; then compounds 3 and 1 (each within the scatter of the next).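

In this assay, for the compounds shown here, 2,3-dimethylphenyl in place of 2-bromophenyl on an amine nitrogen in a ring gives a 2.7-fold lower number from compound 3 to compound 4 (0.43 log units; beyond the scatter), the first single-place step. This position therefore responds to a change of aryl group with the rest of the molecule held fixed, although both groups have one six-membered aromatic ring of carbon only and no hydrogen-bond donors or acceptors. Nothing at hand gives a reason for the step.

Open, as far as these compounds go, is which of the two methyl groups accounts for the step, and whether a methoxy group or a nitrile on this phenyl ring would move the number in the same direction.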